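Replacing a sulfonyl acid chain end with an amide

The source may hold more compounds than are shown below. What is called first, only, known or untested is meant among the compounds shown, and "the series" means these compounds.

Values in a functional assay for inhibition, with Homo sapiens as the target; a lower number here means a stronger inhibitor, a higher number a weaker inhibitor:
- compound 1 `COC(=O)CCCCCCCCn1nc(-c2ccccc2)c(-c2ccccc2)c1-c1ccccc1`: 4300 nM
- compound 2 `O=C(O)CCCCCn1nc(-c2ccccc2)c(-c2ccccc2)c1-c1ccccc1`: > 78000 nM (a limit of the assay, not a number)
- compound 3 `O=C(O)CS(=O)(=O)CCCCCCn1nc(-c2ccccc2)c(-c2ccccc2)c1-c1ccccc1`: 22000 nM

Of the two true numbers, the higher belongs to compound 3, at 22000 nM, so it is the weaker inhibitor of the pair. The next step leads to compound 4 `NC(=O)CCCCCCCCn1nc(-c2ccccc2)c(-c2ccccc2)c1-c1ccccc1`, with 2-carbamoylethyl in place of (carboxymethyl)sulfonyl on a saturated chain carbon, six bonds along the chain from an aromatic nitrogen.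

The closest guide is the measured step of a 5.1-fold higher number from compound 1 to compound 3 (0.71 log units; beyond the scatter), since that step brought in the same (carboxymethyl)sulfonyl group that now leaves. A second step, an at least 18-fold higher number from compound 1 to compound 2 (1.25 log units; beyond the scatter), ends at a limit and gives only a bound. The same is true of an at least 3.5-fold lower number from compound 2 to compound 3 (0.54 log units; beyond the scatter).

Removing the group should therefore partly reverse the first step, so a modest drop is expected: a 2.8-fold lower number from compound 3 to compound 4 (0.44 log units; beyond the scatter). Compound 4 is estimated at 8000 nM, with an expected range of 2000 nM to 35000 nM.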

Compound 4, half-maximal inhibitory concentration: 33000 nM
For compound 4 the middle estimate is 4.1-fold (0.62 log units) below the measured one; the range from low to high includes it.
By their numbers in this assay, from the lowest: compound 1; then compounds 3 and 4 (each within the scatter of the next). At a limit, above all of these: compound 2.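

In this assay, amino in place of methoxy on a carbonyl carbon gives a 7.7-fold higher number from compound 1 to compound 4 (0.89 log units; beyond the scatter), so with the chain held the same, this small change at its end is enough to shift the number beyond the scatter. Putting 2-carbamoylethyl in place of (carboxymethyl)sulfonyl gives a 1.5-fold higher number from compound 3 to compound 4 (0.18 log units; within the scatter), so this assay does not separate these two chain ends, and both sit well short of the methyl ester of compound 1. The remaining step, an at least 2.3-fold lower number from compound 2 to compound 4 (0.37 log units; beyond the scatter), gives only a bound and rests on a limit, not a number: the limit of > 78000 nM in this assay, at which 1 of the 4 values shown sits.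

From the compounds shown here alone, it stays open whether the advantage of compound 1 is specific to its methyl ester, which an ethyl ester or a free carboxylic acid on the same chain could test. A methyl-substituted amide on that chain could also show whether the amide result extends beyond compound 4.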